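Heteroaryl Sulfones as K-ATP Channel Inhibitors

The source may hold more compounds than are shown below. What is called first, only, known or untested is meant among the compounds shown, and "the series" means these compounds.

Measured compounds:
compound 1 `CC(O)(C(=O)Nc1ccc(S(=O)(=O)c2cccnc2)cc1)C(F)(F)F` gives 3500 nM
compound 2 `CC(O)(C(=O)Nc1ccc(S(=O)(=O)c2cnccn2)cc1)C(F)(F)F` gives 12000 nM

In a functional assay (Cavia porcellus) with sulfonylurea receptors; K-ATP channels (Homo sapiens) as the target (on this read-out higher numbers stand for weaker inhibition and lower numbers for stronger inhibition), compound 2 stands highest of the two numbers; its nearest neighbour is compound 1, reached by the step of a 3.4-fold higher number from compound 1 to compound 2 (0.54 log units; beyond the scatter), which exchanges pyridin-3-yl for pyrazin-2-yl on the sulfonyl sulfur. Compound 3 `CC(O)(C(=O)Nc1ccc(S(=O)(=O)c2cncs2)cc1)C(F)(F)F` departs from compound 2 by 1,3-thiazol-5-yl in place of pyrazin-2-yl on a sulfonyl sulfur. Going by the values given here, the single measured step bears on this only loosely: it shows that swapping the ring on the sulfonyl sulfur can move the number by a modest amount beyond the scatter, but it compares two six-membered rings, whereas here a five-membered ring enters. Among the compounds with values here, no measured pair therefore speaks directly for the thiazole, and the direction is open. Given that the shared core with pyridin-3-yl and with pyrazin-2-yl sits within a modest spread, compound 3 is expected to land in the same general region, with the step of a 1.7-fold lower number from compound 2 to compound 3 (0.23 log units; within the scatter) estimated as a slight lowering from compound 2. The estimate for compound 3 is 7000 nM, within a range from 2500 nM to 20000 nM.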

Compound 3, half-maximal inhibitory concentration: 7700 nM
Beside the measured number, compound 3's estimate is 1.1-fold (0.04 log units) below it, and the stated range covers the measured number.
By their numbers in this assay, from the lowest: compound 1; then compounds 3 and 2 (each within the scatter of the next).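

In this assay, the five-membered 1,3-thiazol-5-yl on the sulfonyl sulfur reads much like the six-membered pyrazin-2-yl, with a 1.6-fold lower number from compound 2 to compound 3 (0.19 log units; within the scatter), so at this position the change in ring size, with sulfur entering the ring, does not separate these two compounds beyond the scatter. Against pyridin-3-yl the same ring gives a 2.2-fold higher number from compound 1 to compound 3 (0.34 log units; beyond the scatter), which leaves compound 1 as the strongest inhibitor of the three, since its steps to both other compounds lie beyond the scatter, and places the two rings with two hetero atoms together on the weaker side. Nothing available explains why pyridin-3-yl differs from the other two rings.

The compounds shown leave open how a plain phenyl ring, a pyridine carrying an amine or a simple methyl group on the sulfonyl sulfur would compare, and therefore whether a ring nitrogen matters here at all. From the compounds shown here alone, all three compounds also share one core and are compared in a single read-out, so it remains open whether this ordering of the rings would persist on a different core.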